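This account rests on a few compounds, and the source may have more. Where it says the series, first, only, none or still open, it means among the compounds named here.

Among the compounds with values here, the two compounds measured so far sit close together. Compound 1 `Cn1nc2c(=O)n(CC3(O)CCN(Cc4ccc(-c5cnco5)cc4Cl)CC3)cnc2c1-c1ccc(CN)cc1` gives 71.6 nM in an assay on isolated protein for inhibition of ubiquitin carboxyl-terminal hydrolase 7 (Homo sapiens), with stated times of 30 min and 2 h (on this read-out higher numbers stand for weaker inhibition and lower numbers for stronger inhibition), the higher of the two numbers, while compound 2 `Cn1nc2c(=O)n(CC3(O)CCN(Cc4ccc(-c5ccco5)cc4Cl)CC3)cnc2c1-c1ccc(F)cc1` gives 64.5 nM in this assay; the two values lie within the scatter of each other, so neither can be called the stronger inhibitor. Compound 3 `Cn1nc2c(=O)n(CC3(O)CCN(Cc4ccc(-c5ccc(C(=O)O)o5)cc4Cl)CC3)cnc2c1-c1ccc(CN)cc1` has not yet been measured in this assay. It differs from compound 1 in one place: 5-carboxyfuran-2-yl in place of 1,3-oxazol-5-yl on an aromatic carbon. The change sits on an aromatic carbon of a six-membered aromatic ring of carbon only, meta to a chloro group and para to a large group. Within the data shown here, no pair of measured compounds spans a change of this kind, so there is no step to lean on. The step from compound 1 to compound 3 is expected to be modest, a 1.4-fold higher number from compound 1 to compound 3 (0.15 log units; within the scatter), with no firm direction beyond the scatter. Compound 3 is estimated at 100 nM, within a range of 30 nM to 400 nM.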

Compound 3, half-maximal inhibitory concentration: 753 nM
Compound 3: middle estimate off by 7.5-fold (0.88 log units), on the low side; the whole stated range lies below it.
By their numbers in this assay, from the lowest: compounds 2 and 1 (each within the scatter of the next); then compound 3.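

At this position, meta to a chloro group and para to a large group, the choice of substituent clearly matters in this assay: 5-carboxyfuran-2-yl in place of 1,3-oxazol-5-yl gives an 11-fold higher number from compound 1 to compound 3 (1.02 log units; beyond the scatter). Within the data shown here, this is the first step measured at this place, and it shows that the change moves the read-out towards weaker inhibition rather than leaving it unaltered. No measurement at hand accounts for the size of this step.

The change replaces the ring and adds the carboxylic acid in a single move, and no pair shown separates the share of each. As far as these compounds go, it also remains open whether a methyl ester or a primary amide on the same furan ring would give a number nearer that of compound 1 or that of compound 3.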